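Bromo for methyl on the sulfonamide-bearing ring of the core

The compounds below may be only part of what the source reports. "The series", "measured", "known", "first", "only" and "open" are said of these compounds alone.

Measured compounds:
compound 1, `Cc1cc2c(cc1NS(=O)(=O)c1ccc(-c3ccc(Cl)cc3)cc1)CCN(C)CC2`, 15.9 nM
compound 2, `CN1CCc2ccc(NS(=O)(=O)c3ccc(-c4ccc(C#N)cc4)cc3)cc2CC1`, 25.1 nM
compound 3, `CCCCc1ccc(S(=O)(=O)Nc2ccc3c(c2)CNCC3)cc1`, 25.1 nM; 25.1 nM (2 entries)

In an assay on isolated protein for displacement of a labelled ligand from 5-hydroxytryptamine receptor 6 (Homo sapiens), read by radioligand binding (a lower number here means a stronger inhibitor, a higher number a weaker inhibitor), compound 1 gives the lowest of the two single numbers. Compound 2 comes nearest, and its value lies within the usual scatter of compound 1, so no order between the two can be claimed. Compound 3 contributes two entries rather than one number, and both sit in the same region as compound 2.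

Among the measured compounds shown here, no step between measured compounds differs in a single place, so no measured step is available to calibrate the change considered here. Compound 4, `CN1CCc2cc(Br)c(NS(=O)(=O)c3ccc(-c4ccc(Cl)cc4)cc3)cc2CC1`, differs from compound 1 by bromo in place of methyl on an aromatic carbon. The group that leaves and the group that enters are each a single heavy atom, neither adds nor removes a hydrogen-bond donor or acceptor, and the remainder of the molecule, including the sulfonamide and the biaryl bearing the chloro group, is unchanged.

With nothing in the set to suggest a direction, the expected step of a 1.0-fold higher number from compound 1 to compound 4 (0.00 log units; within the scatter) is small, most likely none beyond the scatter. Compound 4 is therefore estimated at 16 nM in this assay, with a plausible range from 6 nM to 45 nM.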

Compound 4, inhibition constant: 50.1 nM
The estimate for compound 4 lay 3.1-fold (0.50 log units) below the measured number, outside the stated range (above it).
By their numbers in this assay, from the lowest: compounds 1, 2 and 4 (each within the scatter of the next, the first and the last beyond it).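

Among the compounds shown here, this is the first step that differs in one place only, and it shows that the aromatic carbon ortho to a large group is not indifferent to what it carries: in this assay, bromo in place of methyl gives a 3.2-fold higher number from compound 1 to compound 4 (0.50 log units; beyond the scatter) as a modest change beyond the scatter. The two groups match in every count computed for them, each being a single heavy atom with no hydrogen-bond donor or acceptor, so those counts alone do not make them interchangeable at this place, although compound 4 still gives a measurable 50.1 nM in this assay with the rest of the molecule unchanged. Nothing available bears on what lies behind the step.

One exchange at one place cannot separate what is lost with methyl from what is gained with bromo, and a plain hydrogen, chloro, methoxy or an amine on this carbon of the core of compound 1 would be needed to tell these apart. On these data alone, whether the same step holds with the nitrile of compound 2 on the biaryl in place of chloro also remains open.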